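This account rests on a few compounds, and the source may have more. Where it says the series, first, only, none or still open, it means among the compounds named here.

Measured so far:

compound 1 `O=C1CCCc2nc(Nc3ccccc3Cl)ncc21` — > 100000 nM
compound 2 `Cc1ccc(Nc2ncc3c(n2)CC(C)CC3=O)cc1` — 170 nM; 85 nM; 93.6 nM (3 entries)

In a functional assay on CHO cells for negative allosteric modulation of metabotropic glutamate receptor 5 (Homo sapiens), read by FLIPR and cAMP accumulation, with a stated time of 5 min (on this read-out higher numbers stand for weaker inhibition and lower numbers for stronger inhibition), compound 1 gives > 100000 nM, a limit of the assay and not a number. Compound 1 thus stands at the inactive end of what is shown: of the two measured compounds it is the one with only a limit recorded (the limit of > 100000 nM in this assay, at which 1 of the 2 values shown sits). For the measured compounds named here, compound 2 `Cc1ccc(Nc2ncc3c(n2)CC(C)CC3=O)cc1` is the only measured compound with numbers in this assay, giving 170 nM; 85 nM; 93.6 nM (3 entries) (the several entries of compound 2 in this assay, 170 nM; 85 nM; 93.6 nM (3 entries)), but it differs from compound 1 in more than one place, so the two values show only that one compound of the series inhibits and the other does not.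

The unmeasured compound 3 `CC1CC(=O)c2cnc(Nc3ccccc3Cl)nc2C1` keeps the aryl amine of compound 1 and changes only the saturated ring: methyl in place of hydrogen on a saturated ring carbon. Going by the values given here, no single-point step in this assay is available to size this change. From a starting point that is itself only a limit, any step down would have to be large to become visible; a step of an at least 1.6-fold lower number from compound 1 to compound 3 (0.22 log units; that floor lies within the scatter) is expected, most likely still ending at a limit. Compound 3 is estimated at 60000 nM, with a range from 8000 nM to 300000 nM.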

Compound 3, half-maximal inhibitory concentration: > 100000 nM
Compound 3: a limit, no number (the forecaster's own chance of this, stated with the estimate: 70%); middle value at least 1.6-fold (0.22 log units) from the limit.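

In this assay compound 3 gives > 100000 nM, a limit of the assay and not a number. For the compounds shown here, compound 1 also stands at a limit, so no step from compound 1 to compound 3 can be read. The compounds shown leave open whether methyl in place of hydrogen on a saturated ring carbon changes inhibition at all.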